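The source may report more compounds than this note shows. Statements on the series, on what has been measured and on what is new or still open speak of the compounds shown alone.

Compound 1 `CCOC(=O)c1ccc(-c2nn(Cc3ccc(Cl)cc3)c3ccccc23)cc1`: > 10000 nM
Compound 2 `CCOC(=O)c1ccc(-c2nn(Cc3ccc(F)cc3)c3ccccc23)cc1`: > 10000 nM
Compound 3 `CCOC(=O)c1cccc(-c2nn(Cc3ccccc3)c3ccccc23)c1`: > 10000 nM

In a functional assay on cells (Platelet, Homo sapiens) for inhibition (on this read-out higher numbers stand for weaker inhibition and lower numbers for stronger inhibition), compound 1 gives > 10000 nM, which is a limit of the assay and not a number. Compound 2 gives > 10000 nM in this assay, again a limit. Compound 3 gives > 10000 nM, also a limit. Compound 2 thus stands where every measured value stands, at the limit of > 10000 nM in this assay, at which 3 of the 3 values shown sit, and none of the three compounds is resolved from the others. Going by the values given here, the one step between compounds differing in a single place, a step that the two limits leave unreadable from compound 1 to compound 2, is for that reason unreadable in both size and direction.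

Compound 4 `CCCn1nc(-c2ccc(C(=O)OCC)cc2)c2ccccc21` has not yet been measured in this assay. It differs from compound 2 by ethyl in place of 4-fluorophenyl on a saturated chain carbon bound to an aromatic nitrogen; taken one bond further out, 4-fluorobenzyl gives way to propyl. Among the compounds with values here, no measured step bears on this change: the only step available, chloro to fluoro, lies between two limits, and no measured compound varies the group on the saturated chain carbon bound to the aromatic nitrogen. With all values at the limit, the expected step that the limit leaves unreadable from compound 2 to compound 4 has no anchor beyond the limit itself. Compound 4 is therefore expected to give about 20000 nM in this assay, within a range from 3000 nM to 150000 nM, and most likely the assay will again report only a limit.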

Compound 4, half-maximal inhibitory concentration: > 10000 nM
Compound 4: only a limit was reported; the forecaster's own chance of this, stated with the estimate: 80%; the middle value does not contradict the limit.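

In this assay compound 4 gives > 10000 nM, a limit of the assay and not a number. The steps from compound 1 and compound 2 to compound 4 therefore cannot be read, and every value stands at one limit: the limit of > 10000 nM in this assay, at which 4 of the 4 values shown sit.

The compounds shown leave open how far any of these four lies past that limit, and whether any change among them alters inhibition.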